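This account rests on a few compounds, and the source may have more. Where it says the series, first, only, none or still open, it means among the compounds named here.

Working notes on the series. Among the measured compounds shown here, in a functional assay on the whole organism (strain Sprague-Dawley) for inhibition, with Rattus norvegicus as the target, with a stated time of 10 min (on this read-out higher numbers stand for an effect only at larger amounts of compound and lower numbers for an effect already at smaller amounts), compound 1 (`O=C(O)c1cnc(-c2ccccc2)[nH]c1=O`) gives 50 mg/kg, the higher of the two numbers so far, while compound 2 (`O=C(O)c1cnc(-c2ccccc2OCc2ccccc2)[nH]c1=O`) gives 5 mg/kg. Compound 3 (`CCOc1cccc(-c2ncc(C(=O)O)c(=O)[nH]2)c1`) differs from compound 1 by ethoxy in place of hydrogen on an aromatic carbon, which is ethoxy in place of hydrogen on an aromatic carbon. For the measured compounds named here, the only measured step that bears on this is the benzyloxy replacement, a 10-fold lower number from compound 1 to compound 2 (1.00 log units; beyond the scatter), which is modest. With ethoxy as a different group, a smaller step towards lower numbers is expected. The expected change is a 2.5-fold lower number from compound 1 to compound 3 (0.40 log units; beyond the scatter). The estimate for compound 3 is 20 mg/kg, with a range of 6 mg/kg to 60 mg/kg.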

Compound 3, dose for 50% inhibition: 5 mg/kg
Estimate against measurement, compound 3: 4.0-fold (0.60 log units) above, outside the stated range (below it).
By their numbers in this assay, from the lowest: compounds 2 and 3 (each within the scatter of the next); then compound 1.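

In this assay, ethoxy on an aromatic carbon, meta to a large group, gives a 10-fold lower number from compound 1 to compound 3 (1.00 log units; beyond the scatter). A step beyond the scatter therefore does not need a ring in the entering group: ethoxy has none, and its 3 heavy atoms suffice at this place on the core of compound 1. Nothing measured here gives a reason for the size of this step.

Still open, on these data alone, is what a longer chain such as butoxy, or an amine, would give at this place. Also open, as far as these compounds go, is whether ethoxy on another aromatic carbon of this ring would give a step of the same size.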